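From Hydroxy to Dimethylamino on the Amide Chain

The source may hold more compounds than are shown below. What is called first, only, known or untested is meant among the compounds shown, and "the series" means these compounds.

Among the compounds with values here, compound 1 (`C=C(c1ccc(OC)cc1NC(=O)CO)c1ccc(OC)c2c1OC(C)(C)C=C2`) gives 40 nM in a functional assay on A2780 cells (Homo sapiens) for antiproliferative activity, read by MTT assay, with a stated time of 48 h (on this read-out lower numbers stand for stronger inhibition and higher numbers for weaker inhibition), and stands at the potent end of the numbers measured so far. There, compound 2 (`C=C(c1cc(OC)c(OC)c(OC)c1)c1ccc(OC)cc1NC(=O)CN`) gives 30 nM and cannot be separated from compound 1 within the scatter. By contrast, compound 3 (`C=C(c1ccc(OC)cc1NC(=O)CNCC)c1ccc(OC)c2c1C=CC(C)(C)O2`) gives 2010 nM and lies beyond the scatter on the weaker side of compound 1.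

Compound 4 (`C=C(c1ccc(OC)cc1NC(=O)CN(C)C)c1ccc(OC)c2c1OC(C)(C)C=C2`) keeps the core of compound 1 and changes one group, with dimethylamino in place of hydroxy on a saturated chain carbon bound to a carbonyl carbon. Within the data shown here, no pair of measured compounds isolates this change, so any expectation rests on indirect evidence. Nitrogen stands on that chain in two measured compounds, yet their values sit far apart: compound 2 gives 30 nM and compound 3 gives 2010 nM on the same read-out. That spread leaves both outcomes open, and a moderate loss of potency seems the likeliest result. In this assay the expected step, toward a higher number and probably beyond the scatter, is estimated as a 3.8-fold higher number from compound 1 to compound 4 (0.57 log units; beyond the scatter) and remains uncertain. For compound 4 the estimated value is 150 nM with 30 nM to 900 nM as the expected range.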

Compound 4, half-maximal inhibitory concentration: 420 nM
Compound 4: the middle estimate sits 2.8-fold (0.45 log units) below what was measured, and the stated range covers the measured number.
By their numbers in this assay, from the lowest: compounds 2 and 1 (each within the scatter of the next); then compound 4; then compound 3.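

In this assay, within the data shown here, the shared core registers an 11-fold higher number from compound 1 to compound 4 (1.02 log units; beyond the scatter), a large loss and the first step here that isolates a single change. It shows that a group on a saturated chain carbon bound to a carbonyl carbon strongly affects the antiproliferative read-out, and that dimethylamino is a much weaker choice there than hydroxy on this core. The change replaces 1 hydrogen-bond donor with 0 hydrogen-bond donors and 1 heavy atom with 3 heavy atoms, so these two counted differences move together in this single pair and cannot be told apart. Nothing given here explains why the number rises.

The compounds shown leave open whether the loss follows the missing donor or the added atoms, and a methoxy group at the same place on the core of compound 1 would bear directly on that question. They also leave open how a methylamino group or a longer chain ending in dimethylamino would read there, and so whether the response rises gradually or sharply along such a series.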